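A Methoxy Added to a Compound Held at the Limit

The compounds below may be only part of what the source reports. "The series", "measured", "known", "first", "only" and "open" are said of these compounds alone.

Measured so far in a functional assay on Malme-3M cells (Homo sapiens) for cytotoxicity, read by MTT assay, with a stated time of 6 days; a lower number here means that less compound is needed, a higher number that more compound is needed for the effect:
Compound 1 `COC(=O)c1c(-c2ccc([N+](=O)[O-])cc2)oc2ccccc2c1=O`: > 25 ug/mL as a limit
Compound 2 `COC(=O)c1c(-c2ccc(OCc3ccccc3)cc2)oc2ccccc2c1=O`: > 25 ug/mL as a limit
Compound 3 `O=C(O)c1c(-c2ccc([N+](=O)[O-])cc2)oc2ccccc2c1=O`: > 25 ug/mL as a limit

Compound 3 stands at > 25 ug/mL in this assay and this is a limit, not a number. Going by the values given here, it is not alone there, for the series so far shows the limit of > 25 ug/mL in this assay, at which 3 of the 3 values shown sit, and gives no actual number for any compound.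

Compound 4 `COc1ccc2oc(-c3ccc([N+](=O)[O-])cc3)c(C(=O)O)c(=O)c2c1` departs from compound 3 by a single change: methoxy in place of hydrogen on an aromatic carbon on the shared core. Two measured steps lie nearest to it. One is a step that the two limits leave unreadable from compound 1 to compound 2 and the other is a step that the two limits leave unreadable from compound 1 to compound 3 and neither gives a size to carry over. Neither of them places a methoxy in place of hydrogen on an aromatic carbon of the core, so the effect of this change has not been measured directly.

No step beyond the scatter is therefore expected in this assay since compound 3 shares the limit of > 25 ug/mL in this assay, at which 3 of the 3 values shown sit, with both of the others. The estimated change is a number no higher from compound 3 to compound 4 (the limit leaves the size open) and a reading at the limit again is the likeliest result. Compound 4 is expected near 25 ug/mL with an estimated range from 10 ug/mL to 50 ug/mL in this measurement.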

Compound 4, concentration for half-maximal effect: > 25 ug/mL
Compound 4 gave a limit, no number; the forecaster's own chance of this, stated with the estimate: 75%; the middle value sits exactly at the limit.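

In this assay compound 4 gives > 25 ug/mL, which is a limit and not a number. Compound 3 also stands at a limit, so no step can be read between compound 3 and compound 4. The series reads the same throughout: the limit of > 25 ug/mL in this assay, at which 4 of the 4 values shown sit.

The compounds shown leave open what size the methoxy change has, and what actual number any of these compounds would give.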